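The source may report more compounds than this note shows. Statements on the series, on what has been measured and on what is new or still open speak of the compounds shown alone.

Compound 1 `OC(c1ccc(Cl)cc1)(c1cccnc1)c1cccc(F)c1` gives 66000 nM in an ADME assay on L6 cells (Rattus norvegicus) for cytotoxicity, read by resazurin assay, with a stated time of 72 h (on this read-out lower numbers stand for stronger inhibition and higher numbers for weaker inhibition), the only number shown in this set. For compound 2 `N#Cc1cccc(C(O)(c2ccc(Cl)cc2)c2cccnc2)c1` the read-out in this assay is only the limit > 100000 nM, not a number. Going by the values given here, the step of an at least 1.5-fold higher number from compound 1 to compound 2 (0.18 log units; that floor lies within the scatter) is the sole measured comparison, and it touches the same ring that changes in compound 3 `OC(c1ccc(Cl)cc1)(c1cccnc1)c1cncnc1`, which differs from compound 1 by pyrimidin-5-yl in place of 3-fluorophenyl on a saturated chain carbon bound to two aromatic carbons and an oxygen on a saturated carbon. That single step, ending at a limit, points toward a higher number, with the limit of > 100000 nM in this assay, at which 1 of the 2 values shown sits, showing where the ceiling sits. Compound 3 is therefore expected near that ceiling, estimated at 95000 nM (range 45000 nM to 200000 nM), a step of a 1.4-fold higher number from compound 1 to compound 3 (0.16 log units; within the scatter).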

Compound 3, half-maximal inhibitory concentration: > 100000 nM
Compound 3: only a limit was reported (the forecaster's own chance of this, stated with the estimate: 55%); at least 1.0-fold (0.02 log units) between middle value and limit.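

Swapping the whole ring at this position, on a saturated chain carbon bound to two aromatic carbons and an oxygen on a saturated carbon, gives an at least 1.5-fold higher number from compound 1 to compound 3 (0.18 log units; that floor lies within the scatter) in this assay. Unlike the cyano step, this change replaces 3-fluorophenyl itself with pyrimidin-5-yl, and the floor of the step still stays within the scatter. A second, different change at this ring has now ended at the assay limit, which is a limit and not a number: the limit of > 100000 nM in this assay, at which 2 of the 3 values shown sit.

With compound 1 the only number, no order can be read among these compounds. As far as these compounds go, whether an amine or a carboxylic acid on this ring would give a number under the limit stays open.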